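The compounds below may be only part of what the source reports. "The series", "measured", "known", "first", "only" and "open" are said of these compounds alone.

Compound 1 `COc1cccc(OC)c1C(=O)Nc1c[nH]nc1C(=O)NC1CCN(Cc2ccccc2)C1` gives 38000 nM in an ADME assay on MRC5 cells (Homo sapiens) for inhibition, with a stated time of 72 h; on this read-out lower numbers stand for an effect already at smaller amounts and higher numbers for an effect only at larger amounts of compound.
Compound 2 `COc1cccc(OC)c1C(=O)Nc1c[nH]nc1C(=O)N[C@H]1CC[C@H](O)CC1` gives 34000 nM in this assay.
Compound 3 `CO[C@H]1CC[C@H](NC(=O)c2n[nH]cc2NC(=O)c2ccccc2C(F)(F)F)CC1` gives 3300 nM in this assay.

Among these three numbers compound 2 stands second highest. Its nearest neighbour is compound 1, whose value sits within the usual scatter of its own, so no order between compound 1 and compound 2 can be claimed. Compound 3 lies clearly beyond the scatter with a markedly lower number.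

Compound 4 `COc1cccc(OC)c1C(=O)Nc1c[nH]nc1C(=O)NC1CCC(C)CC1` has not been measured. It differs from compound 2 by 4-methylcyclohexyl in place of 4-hydroxycyclohexyl on an amide-type nitrogen. Among the measured compounds shown here, no measured pair shows this change, so the step has to be judged from the change alone: a small shift toward a lower number is expected, probably within the scatter. Compound 4 is therefore expected to give about 25000 nM in this assay, with a range from 10000 nM to 60000 nM, which means an estimated step of a 1.4-fold lower number from compound 2 to compound 4 (0.13 log units; within the scatter).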

Compound 4, half-maximal effective concentration: 45000 nM
Compound 4: the middle estimate sits 1.8-fold (0.26 log units) below what was measured; the measured number falls inside the stated range.
By their numbers in this assay, from the lowest: compound 3; then compounds 2, 1 and 4 (each within the scatter of the next).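

Among the compounds shown here, with 4-methylcyclohexyl in place of 4-hydroxycyclohexyl on an amide-type nitrogen, this assay gives a 1.3-fold higher number from compound 2 to compound 4 (0.12 log units; within the scatter), the first step that can be read at this position. The hydrogen-bond donor and acceptor counted in 4-hydroxycyclohexyl are absent from 4-methylcyclohexyl, yet this pair stays within the scatter. On these data alone, whether an amine or a carboxylic acid in place of the hydroxy group would move the number beyond the scatter remains open. Nothing available explains why this pair stays so close.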